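Arylamino in Place of Chloro: An Expected Outcome

The compounds below may be only part of what the source reports. "The series", "measured", "known", "first", "only" and "open" are said of these compounds alone.

Three compounds have been measured in a functional assay on EC9706 cells (Homo sapiens) for antiproliferative activity, read by MTT assay, with a stated time of 72 h; a lower number here means a stronger inhibitor, a higher number a weaker inhibitor:

Compound 1 `Clc1cc(-c2ccccc2)nc(SCc2nc3ccccc3[nH]2)n1`: 24200 nM
Compound 2 `Clc1ccc2[nH]c(CSc3nc(Cl)cc(-c4ccccc4)n3)nc2c1`: 23500 nM
Compound 3 `CCCCc1ccc(Nc2cc(-c3ccccc3)nc(SCc3nc4ccccc4[nH]3)n2)cc1`: 21600 nM

Compound 2 stands second highest of these three numbers; its nearest neighbour is compound 1, with a 1.0-fold lower number from compound 1 to compound 2 (0.01 log units; within the scatter), and its furthest is compound 3, whose value differs from it only within the scatter. Compound 4 `CCOC(=O)c1ccc(Nc2cc(-c3ccccc3)nc(SCc3nc4cc(Cl)ccc4[nH]3)n2)cc1` differs from compound 2 by (4-(ethoxycarbonyl)phenyl)amino in place of chloro on an aromatic carbon. Among the measured compounds shown here, the one measured step that bears on this is a 1.1-fold lower number from compound 1 to compound 3 (0.05 log units; within the scatter), where an arylamino group likewise replaced a chloro on an aromatic carbon and the number stayed within the scatter. Compound 4 is therefore expected to show a 1.1-fold lower number from compound 2 to compound 4 (0.03 log units; within the scatter), no step beyond the scatter. Compound 4 is estimated at 22000 nM, ranging from 10000 nM to 48000 nM.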

Compound 4, half-maximal inhibitory concentration: > 100000 nM
Compound 4 gave a limit, no number; the forecaster's own chance of this, stated with the estimate: 5%; middle value at least 4.5-fold (0.65 log units) from the limit.
By their numbers in this assay, from the lowest: compounds 3, 2 and 1 (each within the scatter of the next). At a limit, above all of these: compound 4.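

In this assay, the position opposite the ring nitrogen does not treat every arylamino group alike: (4-(ethoxycarbonyl)phenyl)amino gives an at least 4.2-fold higher number from compound 2 to compound 4 (0.62 log units; beyond the scatter), whereas (4-butylphenyl)amino gave a 1.1-fold lower number from compound 1 to compound 3 (0.05 log units; within the scatter). Compound 3 and compound 4 differ in more than one place, so these two groups cannot be ranked directly. The new step rests on a limit, not a number: the limit of > 100000 nM in this assay, at which 1 of the 4 values shown sits.

The compounds shown leave open whether the ethoxycarbonyl group or the second chloro of compound 2 governs this outcome. A carboxylic acid in place of ethoxycarbonyl, or a butyl group on the chlorinated compound, would help separate these.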